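Swapping iodo for chloro in compound 1

A few compounds are considered here, and "the series" means these few. Any claim that something is new, unique, unknown or untested is made for them only; others in the source may bear on it.

Measured in a functional assay on U-87MG ATCC cells (Homo sapiens) for cytotoxicity, read by MTT assay, with a stated time of 48 h; a higher number here means a weaker inhibitor, a lower number a stronger inhibitor:
compound 1 `C/C(=N\NC(=S)Nc1ccccc1I)c1ccccn1`: 6.1 nM
compound 2 `C/C(=N\NC(=S)Nc1ccc(Cl)cc1)c1ccccn1`: 1.7 nM
compound 3 `CC(=NNC(=S)Nc1cccc(I)c1)c1ccccn1`: 84 nM

Compound 1 holds the middle place of these three numbers. Compound 2 lies lower and compound 3 higher, and both gaps from compound 1 are beyond the scatter.

The next compound to be tested is compound 4 `C/C(=N\NC(=S)Nc1ccccc1Cl)c1ccccn1`. It carries chloro in place of iodo on an aromatic carbon, at a site ortho to a large group. Going by the values given here, no measured pair shows this change on its own, so the expectation in this assay rests on indirect evidence. Compound 2, which also bears chloro, gives 1.7 nM, while compound 3, which also bears iodo, gives 84 nM. The same group can therefore come with quite different numbers, and the expected range must stay wide. The estimated step, a 1.2-fold lower number from compound 1 to compound 4 (0.09 log units; within the scatter), is expected to stay within the scatter, with no firm direction. For compound 4 the estimated value is 5 nM, with an expected range from 1.5 nM to 20 nM.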

Compound 4, half-maximal inhibitory concentration: 2.6 nM
For compound 4 the middle estimate is 1.9-fold (0.28 log units) above the measured one; the measured number falls inside the stated range.
By their numbers in this assay, from the lowest: compounds 2 and 4 (each within the scatter of the next); then compound 1; then compound 3.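

In this assay, going by these compounds alone, the swap of iodo for chloro on an aromatic carbon ortho to a large group now has a direct measure, a 2.3-fold lower number from compound 1 to compound 4 (0.37 log units; beyond the scatter), a modest step that the earlier compounds could only hint at. At this site, then, chloro gives the lower number and iodo the higher, though this single pair sets no trend for the same swap elsewhere on the ring. Nothing in the data shown accounts for the size or direction of this step.

Still open, on these data alone, is how other groups would behave at this same site, such as fluoro, bromo, methyl or methoxy. It is also unclear whether an amine or a carboxylic acid there would keep the number low.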